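From benzyl to isopropyl on compound 2

A few compounds are considered here, and "the series" means these few. Any claim that something is new, unique, unknown or untested is made for them only; others in the source may bear on it.

In a functional assay on T98G cells (Homo sapiens) for inhibition, read by MTT assay, with a stated time of 72 h (on this read-out lower numbers stand for stronger inhibition and higher numbers for weaker inhibition), compound 1 `CC1(C)CC(NC(=O)NCc2ccccc2)c2cc(Br)ccc2O1` gives 38000 nM and compound 2 `CC1(C)CC(NC(=O)NCc2ccccc2)c2cc(Cl)ccc2O1` gives 15000 nM, the lower of the two numbers. Compound 3 `CC(C)NC(=O)NC1CC(C)(C)Oc2ccc(Cl)cc21` carries isopropyl in place of benzyl on an amide-type nitrogen. Going by the values given here, the only measured step, a 2.5-fold lower number from compound 1 to compound 2 (0.40 log units; beyond the scatter), is chloro in place of bromo on an aromatic carbon. Among the compounds with values here, it offers a rough guide to size only, and no measured step touches the amide-type nitrogen. In this assay, on these data alone, no step beyond the scatter is therefore expected, and the direction stays open. The estimated change is a 1.5-fold higher number from compound 2 to compound 3 (0.17 log units; within the scatter). For compound 3, the expected value is 22000 nM, with an estimated range of 8000 nM to 60000 nM.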

Compound 3, half-maximal inhibitory concentration: > 100000 nM
Compound 3 gave a limit, no number; the forecaster's own chance of this, stated with the estimate: 15%; middle value at least 4.5-fold (0.65 log units) away from the limit.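

In this assay, going by these compounds alone, the first change at the amide-type nitrogen, benzyl to isopropyl, gives an at least 6.6-fold higher number from compound 2 to compound 3 (0.82 log units; beyond the scatter). Compound 3 stands at a limit and not at a number, so this step has a floor but no known size: the limit of > 100000 nM in this assay, at which 1 of the 3 values shown sits. The result shows that this position responds to the exchange beyond the scatter, with benzyl giving a measurable number and isopropyl only a limit.

The two groups differ in both the six-membered aromatic ring and the heavy-atom count, and the compounds shown do not separate these differences. Cyclohexylmethyl on the same nitrogen, which keeps a ring but not an aromatic one, would bear on this.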